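Removing the Side Chain from the Imidazole Nitrogen

The compounds below may be only part of what the source reports. "The series", "measured", "known", "first", "only" and "open" are said of these compounds alone.

Two compounds give the starting point. Compound 1 `N#Cc1nc(-c2ccc(OCCCO)c(C(F)(F)F)c2)cc2[nH]cnc12` carries a hydroxypropoxy group and an unsubstituted ring nitrogen; in an assay on isolated protein for inhibition of cathepsin S (Homo sapiens), read by fluorescence (on this read-out lower numbers stand for stronger inhibition and higher numbers for weaker inhibition), compound 1 gives 63 nM. Compound 2 `CCOc1ccc(-c2cc3c(ncn3CCN(C)C)c(C#N)n2)cc1C(F)(F)F` carries an ethoxy group and a dimethylaminoethyl chain on the ring nitrogen; in this assay compound 2 gives 32 nM. On these two numbers compound 2 has the lower one, but its gap to compound 1 lies within the scatter, so the two cannot be set in order.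

The step under consideration leads from compound 2 to compound 3 `CCOc1ccc(-c2cc3c(ncn3C)c(C#N)n2)cc1C(F)(F)F`, in which only a methyl remains on that nitrogen: hydrogen in place of (dimethylamino)methyl on a saturated chain carbon bound to an aromatic nitrogen. Among the compounds with values here, no measured pair shows the effect of this change, so its size rests on judgement alone. The nitrile and the aryl group, which the two measured compounds share, remain untouched. For compound 3 the account expects a modest weakening rather than a step beyond the scatter, expressed as a 1.9-fold higher number from compound 2 to compound 3 (0.27 log units; within the scatter). The estimate for compound 3 in this assay is therefore 60 nM, within 20 nM to 180 nM.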

Compound 3, half-maximal inhibitory concentration: 40 nM
Estimate against measurement, compound 3: 1.5-fold (0.18 log units) above; the measured number falls inside the stated range.
By their numbers in this assay, from the lowest: compounds 2, 3 and 1 (each within the scatter of the next).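

Methyl stands in place of the 2-(dimethylamino)ethyl chain on the ring nitrogen, with the ethoxy group, the nitrile and the rest of the shared core unchanged. This change gives in this assay a 1.3-fold higher number from compound 2 to compound 3 (0.10 log units; within the scatter). Within the data shown here, this is the first direct reading at this position, and it shows that, in this pair, a compound without the dimethylamino end of the chain keeps a number within the scatter of the compound that carries it. No measurement is available here that would explain this result.

The compounds shown leave open how this nitrogen responds to other groups, such as a longer chain ending in a morpholine, a chain ending in a carboxylic acid, or plain hydrogen alongside the ethoxy group. They also leave the hydroxypropoxy group and the unsubstituted nitrogen of compound 1 unseparated, for compound 1 differs from compound 2 and from compound 3 in more than one place, and so no single change can be read from it.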